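This account rests on a few compounds, and the source may have more. Where it says the series, first, only, none or still open, it means among the compounds named here.

Measured compounds:
- compound 1, `CC(C(=O)NCc1ccc(C(F)(F)F)cc1OCc1ccc(F)cc1)c1ccc(NS(C)(=O)=O)c(F)c1`: 0.5 nM
- compound 2, `CC(C(=O)NCc1ccc(C(F)(F)F)cc1SCc1ccco1)c1ccc(NS(C)(=O)=O)c(F)c1`: 3.2 nM

In an assay on CHO cells for antagonist activity at transient receptor potential cation channel subfamily V member 1 (Homo sapiens), read by FLIPR (on this read-out higher numbers stand for weaker inhibition and lower numbers for stronger inhibition), compound 1 gives 0.5 nM and compound 2 gives 3.2 nM. For the measured compounds named here, compound 2 therefore holds the highest number of the two measured, the only comparison being compound 1, and the step of a 6.4-fold higher number from compound 1 to compound 2 (0.81 log units; beyond the scatter) shows that exchanging the (4-fluorobenzyl)oxy group for the ((furan-2-yl)methyl)sulfanyl group costs a modest but real amount of inhibition.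

Compound 3, `CC(C(=O)NCc1ccc(C(F)(F)F)cc1-c1ccc(C(C)(C)C)cc1)c1ccc(NS(C)(=O)=O)c(F)c1`, is not yet measured. It differs from compound 2 in one place: 4-(tert-butyl)phenyl in place of ((furan-2-yl)methyl)sulfanyl on an aromatic carbon. Going by the values given here, the only measured step touches the same position, yet it exchanged two groups that are both linked through a single atom, whereas compound 3 carries an aromatic ring attached directly, so that step gives only weak guidance. Compound 3 is therefore expected to land near compound 2, with the step of a 1.6-fold higher number from compound 2 to compound 3 (0.19 log units; within the scatter) expected to stay within the scatter. The estimate for compound 3 in this assay is 5 nM, ranging from 1 nM to 30 nM.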

Compound 3, inhibition constant: 1.1 nM
Compound 3: middle estimate off by 4.5-fold (0.66 log units), on the high side; measured number inside the range.
By their numbers in this assay, from the lowest: compound 1; then compound 3; then compound 2.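

In this assay, this aromatic carbon also accepts a ring attached directly, without a linking atom: 4-(tert-butyl)phenyl in place of ((furan-2-yl)methyl)sulfanyl gives a 2.9-fold lower number from compound 2 to compound 3 (0.46 log units; beyond the scatter), a modest gain in inhibition. The same ring does not match (4-fluorobenzyl)oxy, with a 2.2-fold higher number from compound 1 to compound 3 (0.34 log units; beyond the scatter), so the three groups at this position now fall into a clear order, each separated from the next by more than the scatter. No supporting measurement is available to explain this order.

From the compounds shown here alone, it remains open how much of the gain belongs to the ring and how much to its tert-butyl group, a question that plain phenyl at this carbon would address. Going by these compounds, it is also open how a non-aromatic group, such as a piperidine or a propyl chain, would compare here.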